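The source may report more compounds than this note shows. Statements on the series, on what has been measured and on what is new or still open speak of the compounds shown alone.

Compound 1 `COc1cccc(/C=C2\CCC/C(=C\c3cccc(Cl)c3Cl)C2=O)c1OC`: in an ADME assay on NHDF cells (Homo sapiens) for cytotoxicity, read by MTT assay, with a stated time of 72 h (on this read-out lower numbers stand for stronger inhibition and higher numbers for weaker inhibition), compound 1 reaches only the limit > 50000 nM.
Compound 2 `COc1cccc(/C=C2\CCC/C(=C\c3ccc(O)c(Cl)c3)C2=O)c1OC`: in this assay compound 2 gives 39500 nM.
Compound 3 `COc1ccc(/C=C2\CCC/C(=C\c3ccccc3Br)C2=O)cc1OC`: in this assay compound 3 gives 21800 nM.

Of the two numbers shown, compound 3 gives the lower one, while compound 2 does not stand apart from it beyond the usual scatter, and compound 1 is known only as a limit (the limit of > 50000 nM in this assay, at which 1 of the 3 values shown sits). Compound 4 `COc1ccc(/C=C2\CCC/C(=C\c3ccc(Cl)c(Cl)c3)C2=O)cc1OC` differs from compound 3 in one place: 3,4-dichlorophenyl in place of 2-bromophenyl on a double-bonded chain carbon bound to a double-bonded ring carbon. Within the data shown here, the only measured step that bears on this is an exchange of one chlorinated phenyl for another, an at least 1.2-fold lower number from compound 1 to compound 2 (0.10 log units; that floor lies within the scatter), which did not move beyond the scatter. A change of the same kind is therefore expected to leave compound 4 within the scatter of compound 3, an expected step of a 1.3-fold higher number from compound 3 to compound 4 (0.11 log units; within the scatter). Compound 4 is estimated at 28000 nM, between 12000 nM and 60000 nM.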

Compound 4, half-maximal inhibitory concentration: 10100 nM
Estimate against measurement, compound 4: 2.8-fold (0.44 log units) above; the whole stated range lies above it.
By their numbers in this assay, from the lowest: compound 4; then compounds 3 and 2 (each within the scatter of the next). At a limit, above all of these: compound 1.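

At this place, on a double-bonded chain carbon bound to a double-bonded ring carbon, exchanging one halogen-bearing phenyl for another can move the number in this assay beyond the scatter, with a 2.2-fold lower number from compound 3 to compound 4 (0.33 log units; beyond the scatter) as the first such step; the earlier exchange gave only a floor within the scatter. Nothing measured here explains the step. Still open, on these data alone, is whether the kind of halogen or the number of halogens matters, which 3,4-dibromophenyl could test, and how a phenyl carrying an amine or a carboxylic acid would behave here.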